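The source may hold more compounds than are shown below. What is called first, only, known or untested is meant among the compounds shown, and "the series" means these compounds.

Working notes on the series.

Compound 1 `O=C1NC(=S)S/C1=C\C=C\c1ccccc1` is the plain member of the set. In a functional assay on DLD-1 cells (Homo sapiens), read by microscopy and crystal violet staining, with a stated time of 20 h, tested at 10 ug/mL (a lower number here means less inhibition, a higher number more inhibition at the concentration tested (going by the name of the read-out)), compound 1 gives 81%. Compound 2 `O=C1NC(=S)S/C1=C\C=C\c1ccccc1OS(=O)(=O)c1ccccc1`, which carries an oxygen-linked group on the same aromatic ring, gives 80% in this assay, a reading within the scatter of compound 1. Compound 3 `O=C1NC(=S)S/C1=C\c1cc(Br)ccc1OCc1ccccc1Br`, built on a different aromatic portion, gives 95% in this assay, a reading beyond the scatter above compound 1. On the three numbers, compound 1 stands second highest, closest to compound 2 and furthest from compound 3.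

Compound 4 `O=C1NC(=S)S/C1=C\C=C\c1ccccc1O` is the next member to be run in this assay. It differs from compound 1 by hydroxy in place of hydrogen on an aromatic carbon.

Within the data shown here, no measured pair in the set shows this exact change, so the size of the step can only be judged from the neighbours. Compound 1 gives 81%, and with an oxygen-linked group on this ring compound 2 gives 80%, a reading within the scatter of compound 1. Compound 3 shows that a stronger reading is reachable in this assay, but it changes several places at once. The expected step for compound 4 is therefore small, a number 1 percentage points higher from compound 1 to compound 4 (within the scatter), with no confident direction beyond the scatter. Compound 4 is estimated at 82%, with a range from 68% to 95%.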

Compound 4, a percentage reported as inhibition, at one concentration (the size of the read-out at that concentration, not a potency): 65%
Compound 4: the middle estimate sits 17 percentage points above what was measured, outside the stated range (below it).
By their numbers in this assay, from the lowest: compound 4; then compounds 2 and 1 (each within the scatter of the next); then compound 3.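

In this assay, hydroxy in place of hydrogen on an aromatic carbon, ortho to a large group, gives a number 16 percentage points lower from compound 1 to compound 4 (beyond the scatter), so this position is not indifferent to what it carries. The neighbours had not shown this: compound 1 gives 81% and compound 2, with an oxygen-linked group on the same aromatic ring, gives 80%, while compound 4, with the hydroxy, gives 65%, so an oxygen on this ring does not by itself go with the lower reading. The data on hand offer no measurement that explains the lower reading of compound 4.

From the compounds shown here alone, whether a methoxy group, an amine or a carboxylic acid at this position would stay with compound 4 or return to the level of compound 1 remains open, and so does the effect of moving the hydroxy to another carbon of the ring. Also open is whether the same change would lower the reading on the different aromatic portion of compound 3, since no pair on that portion is shown.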